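The source may hold more compounds than are shown below. What is called first, only, known or untested is meant among the compounds shown, and "the series" means these compounds.

Measured compounds in a functional assay on HUVEC cells (Homo sapiens) for inhibition, read by ELISA; on this read-out lower numbers stand for stronger inhibition and higher numbers for weaker inhibition:

compound 1, `[O-][S+](Cc1ccccc1)c1nnc(-c2ccncc2)o1`, gives 4000 nM
compound 2, `CCCc1nnc([S+]([O-])Cc2ncc(C)c(OC)c2C)o1`, gives 10000 nM
compound 3, `[O-][S+](Cc1ccccc1)c1nnc(-c2cccnc2)o1`, gives 8000 nM

Compound 2 has the highest number of the three. Its gap to compound 3 lies within the scatter of repeated measurements, so the two cannot be set in order; only compound 1 sits beyond the scatter from compound 2. Among the measured compounds shown here, the one step seen so far, a 2.0-fold higher number from compound 1 to compound 3 (0.30 log units; within the scatter), concerns the two pyridyl isomers of compound 1 and compound 3 and does not touch the part of compound 2 that changes here.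

Compound 4, `COc1c(C)cnc(C[S+]([O-])c2nnc(C)o2)c1C`, differs from compound 2 in one place: hydrogen in place of ethyl on a saturated chain carbon bound to an aromatic carbon. For the measured compounds named here, no measured pair shows this change or anything close to it; the propyl chain on the core of compound 2 is otherwise untested. Shortening a chain of this size, where nothing else moves, gives no ground for expecting a step beyond the scatter in either direction in this assay. The estimate for compound 4 therefore stays near the number of compound 2, as a step of no change at the digits printed from compound 2 to compound 4 (within the scatter), with the uncertainty of an unprecedented change added to the usual scatter. Compound 4 is expected to give about 10000 nM, between 4000 nM and 25000 nM.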

Compound 4, half-maximal inhibitory concentration: 10000 nM
Compound 4: middle estimate and measured number agree at the digits printed; measured number inside the range.
By their numbers in this assay, from the lowest: compounds 1, 3, 2 and 4 (each within the scatter of the next, the first and the last beyond it).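

Shortening the propyl chain to methyl, with everything else held fixed, gives in this assay no change at the digits printed from compound 2 to compound 4 (within the scatter). Among the compounds shown here, this is the first reading at this position, since the earlier step concerned only the pyridyl isomers and left the chain on the core untouched; the pair now shows that, at this saturated chain carbon bound to an aromatic carbon, ethyl can give way to hydrogen without the number moving beyond the scatter, although two chain lengths alone define no trend. Nothing measured here accounts for this flat result.

From the compounds shown here alone, whether a longer chain such as hexyl, or a group of another kind such as an amine or a carboxylic acid, would move the number beyond the scatter at this place remains open, as the propyl and methyl compounds cover only a short stretch of what could stand there. Going by these compounds, it also remains open whether the same shortening would read the same way on a compound with a different group on the other side of the sulfoxide, such as the benzyl group of compound 1.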